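The compounds below may be only part of what the source reports. "The series", "measured", "known", "first", "only" and "open" are said of these compounds alone.

Three compounds from one series have been run in a functional assay on CHO cells for positive allosteric modulation of metabotropic glutamate receptor 2 (Homo sapiens), read by scintillation counting and GTPgammaS binding, with a stated time of 30 min (on this read-out lower numbers stand for smaller maximal responses and higher numbers for larger maximal responses), and the numbers set one of them apart. Compound 2 `CC(C)CCn1ccc(-c2ccc(Oc3ccccn3)cc2)c(C#N)c1=O` gives 249%, the highest of the three. Compound 1 `COc1ccc(-c2ccn(CCC(C)C)c(=O)c2C#N)cc1Cl` gives 200% in this assay, a number lower than that of compound 2 by more than the usual scatter. Compound 3 `Cc1cc(Oc2ccc(-c3ccn(CC4CC4)c(=O)c3C#N)cc2)ccn1` gives 199% in this assay, again lower than compound 2 by more than the scatter, so compound 2 stands alone at the top with the other two sitting close to each other below it.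

Compound 4 `Cc1ccc(Oc2ccc(-c3ccn(CCC(C)C)c(=O)c3C#N)cc2)c(C)n1` has not been measured. It differs from compound 2 in one place: 2,6-dimethylpyridin-3-yl in place of pyridin-2-yl on an oxygen on an aromatic ring.

For the measured compounds named here, no pair of measured compounds differs in just this one place, so the size of the step has to be guessed from the wider picture. Compound 3 carries a methyl-bearing pyridinyl group on the same kind of oxygen and its value of 199% lies well under that of compound 2, which makes a drop more plausible than a rise. The step from compound 2 to compound 4 is therefore expected to be a number 39 percentage points lower from compound 2 to compound 4 (beyond the scatter), a modest fall. Compound 4 is estimated at 210%, with a likely range from 150% to 270%.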

Compound 4, largest response reached (Emax), in percent of the reference or control that the assay uses: 246%
Compound 4: middle estimate off by 36 percentage points, on the low side; low and high end bracket the measured number.
By their numbers in this assay, from the lowest: compounds 3 and 1 (each within the scatter of the next); then compounds 4 and 2 (each within the scatter of the next).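

The swap of pyridin-2-yl for 2,6-dimethylpyridin-3-yl on the oxygen can now be read directly, and in this assay it comes out as a number 3 percentage points lower from compound 2 to compound 4 (within the scatter). This position therefore accepts the larger group with its two methyl groups and a different point of attachment to the pyridine ring, with no shift in maximal response beyond the usual scatter, so the high response of compound 2 is not tied to an unsubstituted pyridin-2-yl group. No measurement among these compounds gives a reason for this outcome.

For the compounds shown here, the single step changes the methyl groups and the point of attachment at once, so how much each contributes on its own remains open, and each could be hiding an effect that the other offsets. Also open, as far as these compounds go, is how far this acceptance extends to groups of a different kind at this position, such as an amine or a carboxylic acid on the pyridine ring, or a plain alkyl chain in place of the ring.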